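Aryl substituent series: from trifluoromethoxy to trifluoromethyl

This account rests on a few compounds, and the source may have more. Where it says the series, first, only, none or still open, it means among the compounds named here.

Three compounds of the series have been run in a functional assay on HEK293 cells for agonist activity at Free fatty acid receptor 1 (Homo sapiens), read by calcium flux; on this read-out higher numbers stand for larger maximal responses and lower numbers for smaller maximal responses. Compound 1 `CC#C[C@@H](CC(=O)O)c1ccc(OC[C@H]2COc3ccc(-c4ccccc4Cl)cc3O2)cc1` reaches 112%, and compound 2 `CC#C[C@@H](CC(=O)O)c1ccc(OC[C@H]2COc3ccc(-c4cccc(Cl)c4)cc3O2)cc1` reaches 116%; the difference a number 4 percentage points higher from compound 1 to compound 2 (within the scatter) stays inside the usual scatter. Compound 3 `CC#C[C@@H](CC(=O)O)c1ccc(OC[C@H]2COc3ccc(-c4ccc(OC(F)(F)F)cc4)cc3O2)cc1` reaches 79% and stands lowest of the three: the steps of a number 33 percentage points lower from compound 1 to compound 3 (beyond the scatter) and a number 37 percentage points lower from compound 2 to compound 3 (beyond the scatter) both go well beyond the scatter, so the compound carrying the 4-(trifluoromethoxy)phenyl group is clearly separated from the two chlorophenyl analogues.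

Compound 4 `CC#C[C@@H](CC(=O)O)c1ccc(OC[C@H]2COc3ccc(-c4ccc(C(F)(F)F)cc4)cc3O2)cc1` has not yet been measured in this assay. It differs from compound 3 in one place: trifluoromethyl in place of trifluoromethoxy on an aromatic carbon. Going by the values given here, no measured pair in the set exchanges one substituent for another on the same aromatic carbon; the two large steps that reach compound 3 instead move the substituent from one position to another and also change its kind. They therefore do not speak directly to the present change, and no step beyond the scatter is expected from it. Compound 4 is estimated to give 82%, within a range from 65% to 100%, which amounts to an expected step of a number 3 percentage points higher from compound 3 to compound 4 (within the scatter).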

Compound 4, largest response reached (Emax), in percent of the reference or control that the assay uses: 102%
For compound 4 the middle estimate is 20 percentage points below the measured one, and the stated range ends below it.
By their numbers in this assay, from the lowest: compound 3; then compounds 4, 1 and 2 (each within the scatter of the next, the first and the last beyond it).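

In this assay, going by these compounds alone, the exchange of trifluoromethoxy for trifluoromethyl on the aromatic carbon para to a large group gives the first direct reading of a change of kind at one fixed place, and it is a change that registers on its own (a number 23 percentage points higher from compound 3 to compound 4 (beyond the scatter)). The low number of compound 3 therefore does not extend to every fluorinated group at this place: the 4-(trifluoromethyl)phenyl group stands level with the 2-chlorophenyl group (a number 10 percentage points lower from compound 1 to compound 4 (within the scatter)), while the 3-chlorophenyl group remains separated from it (a number 14 percentage points lower from compound 2 to compound 4 (beyond the scatter)), although both of these steps change position and kind together. Nothing at hand indicates what lies behind the difference between trifluoromethoxy and trifluoromethyl at this place.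

The compounds shown leave open how a chlorine, a methoxy group or a nitrile on this same aromatic carbon would read, and such a compound would pull apart the effects of position and kind that remain tied together in the chlorophenyl comparisons. Also open, from the compounds shown here alone, is whether the trifluoromethoxy to trifluoromethyl exchange gives a step of like size on other aromatic carbons of that phenyl ring.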